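The source may hold more compounds than are shown below. What is called first, only, known or untested is meant among the compounds shown, and "the series" means these compounds.

Of the compounds shown here, three have been measured in an assay on HEK293 cells for displacement of a labelled ligand from 5-hydroxytryptamine receptor 6 (Homo sapiens); on this read-out higher numbers stand for weaker inhibition and lower numbers for stronger inhibition. Compound 1 `O=C1c2ccccc2S(=O)(=O)N1CCCCCCN1CCN(c2cccc(Cl)c2Cl)CC1` stands lowest of the three there: in this assay compound 1 gives 72 nM. Compound 3 `O=C1c2ccccc2S(=O)(=O)N1CCCCCN1CCN(c2ccccc2)CC1` comes nearest, and in this assay compound 3 gives 1840 nM, a number far enough from that of compound 1 to lie beyond the scatter. Compound 2 `COc1ccccc1N1CCN(Cc2ccc(CN3C(=O)c4ccccc4S3(=O)=O)cc2)CC1` lies furthest away, and in this assay compound 2 gives 10100 nM.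

Compound 4 `O=C1c2ccccc2S(=O)(=O)N1CCCCCCN1CCN(c2ncccn2)CC1` has not yet been measured. It differs from compound 1 in one place: pyrimidin-2-yl in place of 2,3-dichlorophenyl on an amine nitrogen in a ring. Among the compounds with values here, no measured pair in this set shows exactly this exchange, so its effect has to be judged without a direct precedent. Since compound 1 is the only one of the three to reach a low number, and neither of the others carries this dichlorophenyl group, a weaker result seems more likely than a stronger one. The step from compound 1 to compound 4 is therefore expected to be a loss of moderate size, an 8.3-fold higher number from compound 1 to compound 4 (0.92 log units; beyond the scatter). In this assay compound 4 is estimated at 600 nM, with a plausible range from 150 nM to 3000 nM.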

Compound 4, inhibition constant: 5710 nM
Compound 4: middle estimate off by 9.5-fold (0.98 log units), on the low side, outside the stated range (above it).
By their numbers in this assay, from the lowest: compound 1; then compound 3; then compounds 4 and 2 (each within the scatter of the next).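

In this assay, putting pyrimidin-2-yl in place of 2,3-dichlorophenyl on an amine nitrogen in a ring gives a 79-fold higher number from compound 1 to compound 4 (1.90 log units; beyond the scatter) while the rest of the molecule stays the same. Within the data shown here, this is the first direct reading of this position, and it shows that the group there has a large effect on the result: a six-membered aromatic ring stands in both compounds, so having such a ring at this position does not by itself keep the number low. Nothing available here explains the size of this step.

This single exchange removes the chlorine atoms and brings in ring nitrogens together, and the effect of each remains unseparated. Pyridin-2-yl or 3-chlorophenyl on the same nitrogen, with the rest of compound 1 unchanged, would help tell the two apart.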